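Ether substituent variation on a shared pyrazolopyridinone core

A few compounds are considered here, and "the series" means these few. Any claim that something is new, unique, unknown or untested is made for them only; others in the source may bear on it.

Measured compounds:
compound 1 `Cc1nn(-c2ncnc3nc[nH]c23)c2c1C(OCC(=O)c1ccc(F)cc1)CC(=O)N2` gives 3 nM in a functional assay on HEK293 cells for agonist activity at G-protein coupled receptor 39 (Homo sapiens), read by scintillation proximity assay and inositol phosphate accumulation, with a stated time of 75 min, in the presence of a further agent that is not named here; a higher number here means that more compound is needed for the effect, a lower number that less compound is needed
compound 2 `CCCCCCCCOC1CC(=O)Nc2c1c(C)nn2-c1ncnc2nc[nH]c12` gives 8 nM in this assay

Compound 2 carries the highest number of the two measured in this assay; its nearest neighbour is compound 1, and the step of a 2.7-fold higher number from compound 1 to compound 2 (0.43 log units; beyond the scatter) separates them, with heptyl in place of (4-fluorophenyl)carbonyl.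

Compound 3 `Cc1nn(-c2ncnc3nc[nH]c23)c2c1C(OCc1ccccc1C#N)CC(=O)N2` is not yet measured. Relative to compound 2 the change is 2-cyanophenyl in place of heptyl on a saturated chain carbon bound to an oxygen on a saturated carbon. For the measured compounds named here, the only step that bears on this is a 2.7-fold higher number from compound 1 to compound 2 (0.43 log units; beyond the scatter), which shows a modest rise when an aryl-bearing group gives way to heptyl. On these data alone, compound 3 returns an aromatic ring to the same place, so a modest movement back toward the number of compound 1 is expected, though the nitrile is untested. The expected step is a 2.0-fold lower number from compound 2 to compound 3 (0.30 log units; within the scatter). For compound 3 the estimate in this assay is 4 nM, within the range 1.5 nM to 12 nM.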

Compound 3, half-maximal effective concentration: 8 nM
Compound 3: middle estimate off by 2.0-fold (0.30 log units), on the low side; measured number inside the range.
By their numbers in this assay, from the lowest: compound 1; then compounds 2 and 3 (each within the scatter of the next).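

In this assay, the step of no change at the digits printed from compound 2 to compound 3 (within the scatter) places 2-cyanophenyl and heptyl within the scatter of each other at this position, so an aromatic ring on the ether chain does not by itself bring the number back to that of compound 1. The step of a 2.7-fold higher number from compound 1 to compound 3 (0.43 log units; beyond the scatter) has the same printed size as a 2.7-fold higher number from compound 1 to compound 2 (0.43 log units; beyond the scatter) and separates compound 1 from both other ethers, while compound 1 differs from compound 3 in both the carbonyl and the aryl substitution. Nothing available gives a reason for these numbers.

On these data alone, it remains open whether the carbonyl or the fluorine of compound 1 accounts for its lower number, a question that phenylcarbonyl without fluorine or 4-fluorobenzyl would address. As far as these compounds go, the response of this position to an amine or a longer chain is also open.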